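One Methyl More on a Saturated Chain

This account rests on a few compounds, and the source may have more. Where it says the series, first, only, none or still open, it means among the compounds named here.

In an ADME assay on Vero cells (Chlorocebus sabaeus) for cytotoxicity, read by resazurin assay, with a stated time of 24 h (a lower number here means that less compound is tolerated, a higher number that more compound is tolerated), compound 1 (`CCCCCO[C@@H]1C=CC(=O)[C@@H](COC(=O)C(C)(C)C)O1`) gives 7380 nM. Compound 2 (`CC(=O)OC[C@H]1O[C@H](OCCC(C)C)C=C([C@H](O)c2ccc([N+](=O)[O-])cc2)C1=O`) gives 14300 nM, within the scatter of compound 1. Compound 3 (`CC(=O)OC[C@H]1O[C@H](OC(C)C)C=CC1=O`) gives 104000 nM, a higher number beyond the scatter of compound 1. Compound 4 (`CCCCCCO[C@@H]1C=CC(=O)[C@@H](COC(=O)C(C)(C)C)O1`) has not yet been measured. It differs from compound 1 by methyl in place of hydrogen on a saturated chain carbon, five bonds along the chain from an oxygen on a saturated carbon. Among the compounds with values here, no measured pair shows this change. In this assay the expected step, a 1.2-fold lower number from compound 1 to compound 4 (0.09 log units; within the scatter), is small, slightly downward and within the scatter. Compound 4 is expected at about 6000 nM, with an estimated range of 2500 nM to 14000 nM.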

Compound 4, half-maximal cytotoxic concentration: 4800 nM
The estimate for compound 4 lay 1.3-fold (0.10 log units) above the measured number, and the stated range covers the measured number.
By their numbers in this assay, from the lowest: compounds 4, 1 and 2 (each within the scatter of the next, the first and the last beyond it); then compound 3.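

In this assay methyl in place of hydrogen on a saturated chain carbon, five bonds along the chain from an oxygen on a saturated carbon, gives a 1.5-fold lower number from compound 1 to compound 4 (0.19 log units; within the scatter) and so provides the first reading of a single change among these compounds. At this position, one more methyl on the saturated chain stays within what repeated measurements would show. Nothing available here bears on the reason for this result.

The compounds shown leave open whether a longer chain would move the number beyond the scatter. They also leave open what an amine or a carboxylic acid in place of this methyl would do.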